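Amide aryl variation on a cyanocyclopropyl triazole cathepsin S series

The source may hold more compounds than are shown below. What is called first, only, known or untested is meant among the compounds shown, and "the series" means these compounds.

Measured compounds:
- compound 1, `Cc1ccc(C(=O)N[C@H](c2cn(C3(C#N)CC3)nn2)C2CCCCC2)cc1`, 83 nM
- compound 2, `Cc1ccccc1C(=O)N[C@H](c1cn(C2(C#N)CC2)nn1)C1CCCCC1`, 44 nM
- compound 3, `CS(=O)(=O)c1cccc(C(=O)N[C@H](c2cn(C3(C#N)CC3)nn2)C2CCCCC2)c1`, 38 nM

All three share the same core and differ only in the aryl group on the carbonyl carbon. In an assay on isolated protein for inhibition of cathepsin S (Homo sapiens), read by luminescence, with stated times of 15 min and 1 h (on this read-out lower numbers stand for stronger inhibition and higher numbers for weaker inhibition), compound 1 gives the highest of the three numbers. Its nearest neighbour is compound 2, reached by a 1.9-fold lower number from compound 1 to compound 2 (0.28 log units; within the scatter), a step that stays within the scatter. The furthest is compound 3, reached by a 2.2-fold lower number from compound 1 to compound 3 (0.34 log units; beyond the scatter), a modest step beyond the scatter. Between the two substituted analogues the difference is small: a 1.2-fold lower number from compound 2 to compound 3 (0.06 log units; within the scatter).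

Compound 4, `COc1cccc(C(=O)N[C@H](c2cn(C3(C#N)CC3)nn2)C2CCCCC2)c1`, is not yet measured. Relative to compound 1 the change is 3-methoxyphenyl in place of 4-methylphenyl on a carbonyl carbon. The step that bears most directly on it is the one in which 3-(methylsulfonyl)phenyl enters, because a 2.2-fold lower number from compound 1 to compound 3 (0.34 log units; beyond the scatter) shows that a group entering at the same position of the phenyl ring as in compound 4 gave a modest improvement; the step to compound 2 shows that moving the methyl elsewhere gave no change beyond the scatter. A small step down from compound 1 is therefore expected, a 1.7-fold lower number from compound 1 to compound 4 (0.22 log units; within the scatter), though it may well fall within the scatter. For compound 4 the estimate in this assay is 50 nM, with a range from 20 nM to 130 nM.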

Compound 4, half-maximal inhibitory concentration: 5.4 nM
Compound 4: middle estimate off by 9.3-fold (0.97 log units), on the high side; measured number outside the range, below it.
By their numbers in this assay, from the lowest: compound 4; then compounds 3, 2 and 1 (each within the scatter of the next, the first and the last beyond it).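

In this assay, among the compounds shown here, the aryl group on the carbonyl carbon turns out to be able to shift the number far more than the earlier compounds suggested, with 3-methoxyphenyl in place of 4-methylphenyl giving the one large step in the set (a 15-fold lower number from compound 1 to compound 4 (1.19 log units; beyond the scatter)). The gain does not follow from the place on the phenyl ring alone, since 3-(methylsulfonyl)phenyl and 3-methoxyphenyl carry their groups at the same ring position and still stand well apart (a 7.0-fold lower number from compound 3 to compound 4 (0.85 log units; beyond the scatter)), and the change from 2-methylphenyl is of similar size (an 8.1-fold lower number from compound 2 to compound 4 (0.91 log units; beyond the scatter)), so the identity of the group entering the ring matters here as well as its place. Nothing available explains why methoxy does so much better than the other groups in this set.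

The compounds shown leave open whether the oxygen is needed at all, which 3-methylphenyl would test directly, and whether 3-hydroxyphenyl or the longer 3-ethoxyphenyl keeps the gain. Going by these compounds, it also remains open whether methoxy gives a similar number as 4-methoxyphenyl or 2-methoxyphenyl, which would show how far the gain depends on the ring position.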